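Lengthening the Chain on Compound 3

This account rests on a few compounds, and the source may have more. Where it says the series, first, only, none or still open, it means among the compounds named here.

Among the measured compounds shown here, compound 3 `CCCCNNC(=O)c1ccc(-c2ccc(CNC(C)=O)cc2)cc1` is one of three compounds measured in an assay on isolated protein for inhibition of histone deacetylase 8 (Homo sapiens), read by fluorescence, with a stated time of 5 min; a lower number here means a stronger inhibitor, a higher number a weaker inhibitor. In this assay compound 3 gives 360 nM, the highest of the three numbers. Compound 1 `CCCNNC(=O)c1cnc(N2CCN(C)CC2)nc1` gives 250 nM, which lies within the scatter of compound 3. Compound 2 `CCCCCCNNC(=O)c1cnc(NCc2ccccc2)nc1` gives 16 nM, well beyond the scatter, but it carries a different core, so its number cannot be tied to any single feature.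

Compound 4 `CCCCCNNC(=O)c1ccc(-c2ccc(CNC(C)=O)cc2)cc1` differs from compound 3 by one change: methyl in place of hydrogen on a saturated chain carbon, four bonds along the chain from an amine nitrogen. For the measured compounds named here, no step of exactly this kind is among the measured pairs, so I expect a step from compound 3 to compound 4 of roughly a 1.4-fold lower number from compound 3 to compound 4 (0.16 log units; within the scatter), likely toward a lower number but possibly none beyond the scatter. For compound 4 I estimate 250 nM, in a range from 100 nM to 700 nM.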

Compound 4, half-maximal inhibitory concentration: 350 nM
Compound 4: middle estimate off by 1.4-fold (0.15 log units), on the low side, and the stated range covers the measured number.
By their numbers in this assay, from the lowest: compound 2; then compounds 1, 4 and 3 (each within the scatter of the next).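

In this assay, among the compounds shown here, the pair of compound 3 and compound 4 gives the first step in which only one place changes: methyl in place of hydrogen on a saturated chain carbon, four bonds along the chain from an amine nitrogen, gives a step within the scatter (a 1.0-fold lower number from compound 3 to compound 4 (0.01 log units; within the scatter)). On this core, then, adding this one carbon leaves the number effectively flat. No measurement shown here offers a reason for this result.

Still open, from the compounds shown here alone, is whether a longer chain, such as heptyl, would also leave the number flat on this core. A chain ending in an amine or a carboxylic acid is equally untested among the compounds shown.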